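This account rests on a few compounds, and the source may have more. Where it says the series, first, only, none or still open, it means among the compounds named here.

Of the compounds shown here, three have numbers so far in a functional assay on SU-DHL-6 cells (Homo sapiens) for cytotoxicity, read by luminescence, with a stated time of 4 days; on this read-out higher numbers stand for weaker inhibition and lower numbers for stronger inhibition. Compound 1 (`COc1c([C@H](C)Nc2ncnc3[nH]cnc23)cc(Cl)c(C)c1-c1cnn(C)c1`) gives 100 nM and compound 3 (`C[C@H](Nc1ncnc2[nH]cnc12)c1cc(Cl)c2cccnc2c1-c1cccc(F)c1`) gives 140 nM, two values within the scatter of each other. Compound 2 (`COc1c([C@H](C)Nc2ncnc(N)c2C#N)cc(Cl)c(C)c1-c1ccc(C(=O)N(C)C)cn1`) gives 21 nM, the lowest of the three, and its distance to each of the other two lies beyond the scatter.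

Compound 4 (`COc1c([C@H](C)Nc2ncnc(N)c2C#N)cc(Cl)c(C)c1-c1cncc(S(C)(=O)=O)c1`) has not yet been measured in this assay. It carries 5-(methylsulfonyl)pyridin-3-yl in place of 5-(dimethylcarbamoyl)pyridin-2-yl on an aromatic carbon, ortho to a methoxy group and ortho to a methyl group: 5-(methylsulfonyl)pyridin-3-yl in place of 5-(dimethylcarbamoyl)pyridin-2-yl on an aromatic carbon. For the measured compounds named here, no measured pair isolates a change at this place, so the expectation rests on little. A modest upward step is expected, most likely within the scatter, because compound 2 already stands lowest at 21 nM. The estimated move is a 1.7-fold higher number from compound 2 to compound 4 (0.22 log units; within the scatter). For compound 4 the estimated value is 35 nM, with an expected range of 12 nM to 100 nM.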

Compound 4, half-maximal inhibitory concentration: 3.1 nM
Estimate against measurement, compound 4: 11-fold (1.05 log units) above; measured number outside the range, below it.
By their numbers in this assay, from the lowest: compound 4; then compound 2; then compounds 1 and 3 (each within the scatter of the next).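

In this assay, exchanging 5-(dimethylcarbamoyl)pyridin-2-yl for 5-(methylsulfonyl)pyridin-3-yl gives a 6.8-fold lower number from compound 2 to compound 4 (0.83 log units; beyond the scatter) and shows that this aromatic carbon, ortho to a methoxy group and ortho to a methyl group, still has room for a lower number beyond that of compound 2. This is the only pair shown that isolates a change at this place, but the exchange alters the ring attachment and the ring substituent together, so the step cannot be assigned to either one. No measurement shown bears on the reason for the step.

On these data alone, it remains open whether the lower number follows the methylsulfonyl group or the pyridin-3-yl attachment, which a pyridin-3-yl ring carrying dimethylcarbamoyl would help to separate. As far as these compounds go, how a primary sulfonamide or a carboxylic acid on the same ring would read in this assay also remains open.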